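The source may report more compounds than this note shows. Statements on the series, on what has been measured and on what is new or still open speak of the compounds shown alone.

Measured in an assay on CHO cells for displacement of a labelled ligand from 5-hydroxytryptamine receptor 7 (Homo sapiens); a lower number here means a stronger inhibitor, a higher number a weaker inhibitor:
compound 1 `CCC1(CCCCN2CCN(c3cccc(Cl)c3)CC2)C(=O)Nc2ccccc21` gives 0.41 nM
compound 2 `CCC1(CCCCCN2CCN(c3cccc(Cl)c3)CC2)C(=O)Nc2ccccc21` gives 1.45 nM
compound 3 `CC(C)CC1(CCCCN2CCN(c3cccc(Cl)c3)CC2)C(=O)Nc2ccccc21` gives 1.8 nM

Compound 1 has the lowest number of the three, and compound 2 sits at a higher value than it. Within the data shown here, the one single-point step measured, a 4.4-fold higher number from compound 1 to compound 3 (0.64 log units; beyond the scatter), is modest and lies beyond the scatter. Compound 4 `CCC1(CCCCN2CCN(c3ccccc3Cl)CC2)C(=O)Nc2ccccc21` keeps everything in compound 1 but with 2-chlorophenyl in place of 3-chlorophenyl on an amine nitrogen in a ring. Neither measured step touches the chlorophenyl ring, so there is no direct guide; the steps on the chain show that small changes to compound 1 have so far raised the number modestly. A similar modest rise is expected here, a 4.9-fold higher number from compound 1 to compound 4 (0.69 log units; beyond the scatter). Compound 4 is therefore estimated at 2 nM, with a range from 0.5 nM to 10 nM.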

Compound 4, inhibition constant: 5.11 nM
Compound 4: middle estimate off by 2.6-fold (0.41 log units), on the low side; measured number inside the range.
By their numbers in this assay, from the lowest: compound 1; then compounds 2 and 3 (each within the scatter of the next); then compound 4.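

Swapping 3-chlorophenyl for 2-chlorophenyl adds and removes no atoms, yet it gives a 12-fold higher number from compound 1 to compound 4 (1.10 log units; beyond the scatter) in this assay. Among these compounds, this is the first measured change to the chlorophenyl group, and it shows that the number here depends strongly on where the chlorine sits on that ring, not just on its presence. Nothing available explains why this placement matters.

Still open, as far as these compounds go, is how a plain phenyl group would compare, or a ring carrying fluorine or a methoxy group in place of chlorine.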